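Phenylsulfonyl in place of benzoyl: expected effect on inhibition

This account rests on a few compounds, and the source may have more. Where it says the series, first, only, none or still open, it means among the compounds named here.

In an assay on isolated protein for inhibition of 3',5'-cyclic-AMP phosphodiesterase 4A (Cavia porcellus), read by cAMP accumulation, tested at 100 uM (on this read-out higher numbers stand for a stronger effect at the one concentration tested and lower numbers for a weaker effect), compound 1 `O=C(c1ccccc1)c1cc(C(=O)c2ccccc2)c(=O)[nH]c1-c1ccccc1` gives 9.6%. Compound 3 `CC(=O)c1cc(S(=O)(=O)c2ccccc2)c(=O)[nH]c1C` gives 8.72% and compound 2 `O=C1CC(c2ccccc2)Cc2[nH]c(=O)c(C(=O)c3ccccc3)cc21` gives 7.8%; the three numbers lie within the scatter of one another, so none of them can be set apart. Compound 4 `O=C(c1ccccc1)c1cc(S(=O)(=O)c2ccccc2)c(=O)[nH]c1-c1ccccc1` has not yet been measured. It differs from compound 1 in one place: phenylsulfonyl in place of benzoyl on an aromatic carbon. Among the compounds with values here, no pair of measured compounds differs in a single place, so no measured step guides the expectation. Compound 3 already carries a phenylsulfonyl group, and in this assay compound 3 gives 8.72%, a number in the same range as compound 1. The expected change is a number 0.6 percentage points lower from compound 1 to compound 4 (within the scatter), no more than the scatter. For compound 4 the estimate is 9%, with a range from 0% to 22%.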

Compound 4, a percentage reported as inhibition, at one concentration (the size of the read-out at that concentration, not a potency): 7.53%
Compound 4: the middle estimate sits 1.5 percentage points above what was measured; the range from low to high includes it.
By their numbers in this assay, from the lowest: compounds 4, 2, 3 and 1 (each within the scatter of the next).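

In this assay, phenylsulfonyl in place of benzoyl on the aromatic carbon para to a phenyl group gives the only single-place step among the compounds shown: a number 2.1 percentage points lower from compound 1 to compound 4 (within the scatter). On the core of compound 1, this exchange therefore stays within the scatter at the one concentration tested. No measured evidence bears on this result.

From the compounds shown here alone, whether another group at this position, such as an amine or a carboxylic acid, would give a step beyond the scatter remains open. Going by these compounds, the read-out gives only the size of the effect at one concentration, so how the compounds compare at other concentrations also remains open.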